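A few compounds are considered here, and "the series" means these few. Any claim that something is new, unique, unknown or untested is made for them only; others in the source may bear on it.

In an assay on HEK293 cells for positive allosteric modulation of metabotropic glutamate receptor 5 (Homo sapiens), read by FLIPR, with a stated time of 1 h (a higher number here means that more compound is needed for the effect, a lower number that less compound is needed), compound 2 `CC1CC(C(=O)N2CCc3nc(C#Cc4ccccc4)sc3C2)C1` gives 81 nM. For the measured compounds named here, that is the only number in hand: the other measured compound, compound 1 `COc1ccccc1C#Cc1nc2c(s1)C(=O)NCC2`, is described only by the limit of > 10000 nM in this assay, at which 1 of the 2 values shown sits. Going by the values given here, for compound 1 the entry > 10000 nM is a limit of the assay, not a measured number, so nothing can be said about how far apart the two compounds really lie, and no step between measured compounds can be drawn from them. Compound 2 is therefore the sole point of reference for anything that follows.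

Compound 3 `Cc1nc(C(=O)N2CCc3nc(C#Cc4ccccc4)sc3C2)cs1` differs from compound 2 at a single place, the group attached to the carbonyl carbon of the amide: 2-methyl-1,3-thiazol-4-yl in place of 3-methylcyclobutyl on a carbonyl carbon. One flat aromatic piece with two hetero atoms takes the place of a small saturated carbon ring. Among the compounds with values here, with no measured step of this kind to lean on, the expected change is a 1.9-fold higher number from compound 2 to compound 3 (0.27 log units; within the scatter), a modest move toward more compound being needed, of a size close to the usual scatter. Compound 3 is accordingly expected to give about 150 nM, within a range from 40 nM to 600 nM.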

Compound 3, half-maximal effective concentration: 220 nM
For compound 3 the middle estimate is 1.5-fold (0.17 log units) below the measured one; the measured number falls inside the stated range.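

Swapping 3-methylcyclobutyl for 2-methyl-1,3-thiazol-4-yl on the carbonyl carbon gives a 2.7-fold higher number from compound 2 to compound 3 (0.43 log units; beyond the scatter), the first measured step at this position in this assay. The position is therefore not indifferent to the group it carries, but the size of the step is modest, and a saturated carbon ring is not required for a measurable result, as compound 3 gives 220 nM. Compound 1 still offers no comparison, since its entry is a limit and not a number: the limit of > 10000 nM in this assay, at which 1 of the 3 values shown sits.

This single step changes several things at once, including the ring size, the aromatic character and the hetero atoms, so it cannot show which of them accounts for the higher number, and no cause for the step can be given. The compounds shown also leave open how this position would respond to a phenyl ring, a plain cyclobutyl ring without its methyl, an open chain such as isobutyl, or a ring carrying an amine, and whether any of these would give a lower number than compound 2.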